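This account rests on a few compounds, and the source may have more. Where it says the series, first, only, none or still open, it means among the compounds named here.

Compound 1 `C=CCc1ccc(OCc2cn(-c3ccccc3Cl)nn2)c(O)c1`: 34.3%
Compound 2 `C=CCc1ccc(OCc2cn(-c3ccc(C(=O)c4ccccc4)cc3)nn2)c(O)c1`: 35.6%

In a functional assay on MCF7 cells (Homo sapiens) for inhibition, read by MTT assay, with a stated time of 72 h, tested at 50 uM (on this read-out lower numbers stand for less inhibition of growth and higher numbers for more inhibition of growth at the one concentration tested), compound 2, at 35.6%, lies within the scatter of compound 1, so neither stands apart. Compound 3 `C=CCc1ccc(OCc2cn(-c3ccc(Br)cc3)nn2)c(O)c1` follows from compound 2 by one change: bromo in place of benzoyl on an aromatic carbon. In words, bromo replaces benzoyl on an aromatic carbon, para to a large group. Among the compounds with values here, no measured step covers this change. Within the data shown here, the two values show only that compound 1 and compound 2 sit level despite their different substituents. The expected step is a number 0.6 percentage points lower from compound 2 to compound 3 (within the scatter), with no change beyond the scatter and no direction favoured. Compound 3 is estimated at 35%, with an expected range of 22% to 48%.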

Compound 3, percent growth inhibition at one concentration: 29.1%
For compound 3 the middle estimate is 5.9 percentage points above the measured one, and the stated range covers the measured number.
By their numbers in this assay, from the lowest: compounds 3, 1 and 2 (each within the scatter of the next).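

In this assay, benzoyl at this position, para to a large group, gives way to bromo with a number 6.5 percentage points lower from compound 2 to compound 3 (within the scatter), so the whole benzoyl group can go without a shift beyond the scatter. Likewise, 4-bromophenyl in place of 2-chlorophenyl on an aromatic nitrogen gives a number 5.2 percentage points lower from compound 1 to compound 3 (within the scatter), so all three aryl variants remain level. Nothing available explains this flatness. From the compounds shown here alone, whether an amine or a carboxylic acid at this position would move the number beyond the scatter remains open.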